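Nitro in place of imidazolyl on a chalcone scaffold

A few compounds are considered here, and "the series" means these few. Any claim that something is new, unique, unknown or untested is made for them only; others in the source may bear on it.

Compound 1 `COc1cccc(/C=C/C(=O)c2ccc(OC)c3c2OC(C)(C)C=C3)c1` — > 10000 nM
Compound 2 `COc1ccc(C(=O)/C=C/c2ccc(N3CCCC3)cc2)c2c1C=CC(C)(C)O2` — 8360 nM
Compound 3 `COc1ccc(C(=O)/C=C/c2ccc(-n3ccnc3)cc2)c2c1C=CC(C)(C)O2` — > 6600 nM

Three compounds share a core and were measured in a functional assay on HT-29 cells (Homo sapiens) for antiproliferative activity, read by MTT assay, with a stated time of 24 h; on this read-out lower numbers stand for stronger inhibition and higher numbers for weaker inhibition. Compound 2 `COc1ccc(C(=O)/C=C/c2ccc(N3CCCC3)cc2)c2c1C=CC(C)(C)O2` gives 8360 nM. For compound 1 `COc1cccc(/C=C/C(=O)c2ccc(OC)c3c2OC(C)(C)C=C3)c1` the value > 10000 nM is a limit of the assay and not a number; it is the limit described in the limit of > 10000 nM in this assay, at which 1 of the 3 values shown sits. For compound 3 `COc1ccc(C(=O)/C=C/c2ccc(-n3ccnc3)cc2)c2c1C=CC(C)(C)O2` the value > 6600 nM is likewise a limit and not a number, the one described in the limit of > 6600 nM in this assay, at which 1 of the 3 values shown sits. Within the data shown here, compound 3 therefore stands at a limit, and the only step reaching it, a step that the limit leaves unreadable from compound 2 to compound 3, cannot be read for its size.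

Compound 4 `COc1ccc(C(=O)/C=C/c2ccc([N+](=O)[O-])cc2)c2c1C=CC(C)(C)O2` differs from compound 3 in one place: nitro in place of 1H-imidazol-1-yl on an aromatic carbon. Among the measured compounds shown here, no measured step involves a nitro group, so the expectation rests on the weak values shown throughout. Compound 4 is expected to give 8000 nM in this assay, with a range from 3000 nM to 20000 nM, and the expected step that the limit leaves unreadable from compound 3 to compound 4 is not beyond the scatter.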

Compound 4, half-maximal inhibitory concentration: 3730 nM
For compound 4 the middle estimate is 2.1-fold (0.33 log units) above the measured one; low and high end bracket the measured number.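

In this assay, among these compounds, nitro gives the first step at this place, para to a large group, that can be read beyond the scatter: a 2.2-fold lower number from compound 2 to compound 4 (0.35 log units; beyond the scatter). The other two steps are floors only, one with nitro replacing 1H-imidazol-1-yl, an at least 1.7-fold lower number from compound 3 to compound 4 (0.24 log units; that floor lies within the scatter), and one with 4-nitrophenyl replacing 3-methoxyphenyl, an at least 2.6-fold lower number from compound 1 to compound 4 (0.42 log units; beyond the scatter). From the compounds shown here alone, compound 3 and compound 1 each stand at a limit and not a number, so the true size of these two steps remains unknown.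

The compounds shown do not tell what lies behind the lower number with nitro, since they hold no measured property of the groups. Going by these compounds, whether a nitrile or a carboxylic acid on the same aromatic carbon would give a lower number still remains open.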